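Lengthening the nitrile-bearing chain of compound 3

The source may hold more compounds than are shown below. What is called first, only, known or untested is meant among the compounds shown, and "the series" means these compounds.

Measured compounds in an assay on isolated protein for binding affinity to leukotriene B4 receptor 1 (Homo sapiens), tested at 1 uM; a higher number here means more inhibition at the concentration tested (going by the name of the read-out), a lower number less inhibition:
compound 1, `CCCc1cc(C(C)=O)c(O)cc1OCCCCC#N`: 37%
compound 2, `CCCCCc1cc(C(C)=O)c(O)cc1OCCCCC#N`: 14%
compound 3, `C=CCc1cc(C(C)=O)c(O)cc1OCC#N`: 2%

Compound 3 stands lowest of the three numbers, separated from compound 2 and further from compound 1 by gaps beyond the scatter. Compound 4, `C=CCc1cc(C(C)=O)c(O)cc1OCCCCCCC#N`, differs from compound 3 in one place: 5-cyanopentyl in place of cyano on a saturated chain carbon bound to an oxygen on an aromatic ring. Within the data shown here, the only measured single-point step, a number 23 percentage points lower from compound 1 to compound 2 (beyond the scatter), concerns the saturated chain on the other side of the shared core and does not touch the nitrile chain, so no measured step bears directly on this change. What the data do show is that compound 1 and compound 2, which carry a longer nitrile chain than compound 3, give higher numbers than compound 3, but they also differ from it elsewhere, so this comparison is only suggestive. A moderate rise in this assay is therefore expected, with wide uncertainty. Compound 4 is estimated at 25%, with a plausible range from 5% to 50%, meaning an expected step of a number 23 percentage points higher from compound 3 to compound 4 (beyond the scatter).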

Compound 4, a percentage reported as inhibition, at one concentration (the size of the read-out at that concentration, not a potency): 63%
For compound 4 the middle estimate is 38 percentage points below the measured one; the measured number lies above the stated range.
By their numbers in this assay, from the lowest: compound 3; then compound 2; then compound 1; then compound 4.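

Putting 5-cyanopentyl in place of cyano on a saturated chain carbon bound to an oxygen on an aromatic ring gives, in this assay, a number 61 percentage points higher from compound 3 to compound 4 (beyond the scatter), the first single-place step measured at this position, and it shows that the number responds strongly to a change here. Both groups carry a nitrile and match in triple bonds, hydrogen-bond donors, hydrogen-bond acceptors and net charge, so the counted difference lies in the carbons of the entering chain. The earlier single-place step, a number 23 percentage points lower from compound 1 to compound 2 (beyond the scatter), also lengthened a chain but went the other way, so a longer chain does not raise the number at every place on the shared core.

Going by these compounds, with only these two groups at this position, it remains open whether the number climbs steadily with each added carbon or peaks at some length, whether a still longer chain would go further, and whether the nitrile could give way to a carboxylic acid or an amine at the chain end. No measurement here explains why this longer chain gives the higher number.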